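This account rests on a few compounds, and the source may have more. Where it says the series, first, only, none or still open, it means among the compounds named here.

Of the compounds shown here, two from one series have been tested in a functional assay on SNB-75 cells (Homo sapiens) for inhibition, read by sulforhodamine B assay, with a stated time of 48 h; a lower number here means a stronger inhibitor of growth, a higher number a weaker inhibitor of growth. Compound 1 `Cc1cc(O)cc(-c2nn(CC#N)cc2-c2ccnc(-c3ccc(Oc4ccccc4)cc3)c2)c1` gives 17100 nM. Compound 2 `COc1cc(C)cc(-c2nn(CC#N)cc2-c2ccnc(-c3ccc(N(C)C)cc3)c2)c1` gives 848 nM, the lowest of the two numbers and beyond the scatter apart from compound 1. Compound 3 `Cc1cc(O)cc(-c2nn(CC#N)cc2-c2ccnc(-c3ccc(N(C)C)cc3)c2)c1` is not yet measured; it differs from compound 2 by hydrogen in place of methyl on an oxygen on an aromatic ring. Within the data shown here, no measured pair isolates this change, so there is no direct guide to its size. The step expected in this assay is a 1.3-fold higher number from compound 2 to compound 3 (0.11 log units; within the scatter), that is, nothing beyond the scatter in either direction. For compound 3 the estimate is 1100 nM, with a range from 350 nM to 3500 nM.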

Compound 3, concentration for total growth inhibition: 5940 nM
For compound 3 the middle estimate is 5.4-fold (0.73 log units) below the measured one; measured number outside the range, above it.
By their numbers in this assay, from the lowest: compound 2; then compound 3; then compound 1.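

In this assay the methyl on the oxygen of the 3-methoxy-5-methylphenyl group turns out to matter: hydrogen in its place gives a 7.0-fold higher number from compound 2 to compound 3 (0.85 log units; beyond the scatter) and so this one-carbon change is not silent. With the hydroxy held fixed, dimethylamino in place of phenoxy gives a 2.9-fold lower number from compound 1 to compound 3 (0.46 log units; beyond the scatter) and so that second place also moves the number. Nothing given here explains either step. Still open, from the compounds shown here alone, is whether an ethoxy group or a longer chain on that oxygen, or an amine in place of the hydroxy, would match compound 2 or go beyond it.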